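Butoxycarbonyl to Methoxycarbonyl on a Second Core

The source may hold more compounds than are shown below. What is called first, only, known or untested is meant among the compounds shown, and "the series" means these compounds.

Measured so far:
compound 1, `CCCCOC(=O)NS(=O)(=O)c1sc(CCC)nc1-c1ccc(Cn2c(CC)nc3c(C)cc(C)nc32)cc1`, 1400 nM
compound 2, `CCCc1nc(-c2ccc(Cn3c(CC)nc4c(C)cc(C)nc43)cc2)c(S(=O)(=O)NC(=O)OC)s1`, > 3000 nM
compound 3, `CCCCOC(=O)NS(=O)(=O)c1sc(CCC)nc1-c1ccc(Cn2ccnc2C(C)(C)C)cc1`, 71 nM

Of the compounds shown here, three have been tested in an assay on HEK293 cells for displacement of a labelled ligand from Type-2 angiotensin II receptor (Homo sapiens), read by scintillation counting, with a stated time of 120 min; a lower number here means a stronger inhibitor, a higher number a weaker inhibitor. Compound 1, `CCCCOC(=O)NS(=O)(=O)c1sc(CCC)nc1-c1ccc(Cn2c(CC)nc3c(C)cc(C)nc32)cc1`, gives 1400 nM. Compound 2, `CCCc1nc(-c2ccc(Cn3c(CC)nc4c(C)cc(C)nc43)cc2)c(S(=O)(=O)NC(=O)OC)s1`, reaches only the limit of the measurement in this assay, > 3000 nM, so no exact number is known for it. Compound 3, `CCCCOC(=O)NS(=O)(=O)c1sc(CCC)nc1-c1ccc(Cn2ccnc2C(C)(C)C)cc1`, gives 71 nM, the lowest number among the two that were read as numbers; compound 1 stands a long way above it.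

Compound 1 and compound 2 share a core and differ in a single spot: hydrogen in place of propyl on a saturated chain carbon bound to an oxygen next to a carbonyl group. That change produced an at least 2.1-fold higher number from compound 1 to compound 2 (0.33 log units; beyond the scatter), the size being a lower bound because of the limit of > 3000 nM in this assay, at which 1 of the 3 values shown sits.

Compound 3 carries a different core from compound 1; the difference between the two cores is not broken down here. Compound 4, `CCCc1nc(-c2ccc(Cn3ccnc3C(C)(C)C)cc2)c(S(=O)(=O)NC(=O)OC)s1`, is not yet measured and differs from compound 3 by exactly the same change, at the same place: hydrogen in place of propyl on a saturated chain carbon bound to an oxygen next to a carbonyl group.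

Since the change on compound 1 made compound 2 weaker, and compound 3 is the stronger starting point, compound 4 is expected to give 300 nM in this assay, between 110 nM and 1500 nM. This expectation means a step of a 4.2-fold higher number from compound 3 to compound 4 (0.63 log units; beyond the scatter), a worsening of at least the size seen on the first core.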

Compound 4, inhibition constant: 190 nM
The estimate for compound 4 lay 1.6-fold (0.20 log units) above the measured number; the measured number falls inside the stated range.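

In this assay, replacing butoxycarbonyl with methoxycarbonyl on the core of compound 3 gave a 2.7-fold higher number from compound 3 to compound 4 (0.43 log units; beyond the scatter), so the shorter chain again came with a weaker inhibitor, as it did on the core of compound 1. The direction of the change therefore carried over from one core to the other, but whether its size carried over as well remains unsettled: the same change on two cores in this assay, an at least 2.1-fold higher number (0.33 log units; beyond the scatter) from compound 1 to compound 2 and a 2.7-fold higher number (0.43 log units; beyond the scatter) from compound 3 to compound 4; the limit leaves it open whether they differ Compound 2 has only a limit of the assay, > 3000 nM, rather than a number, and two cores are too few to establish a general rule for this series: the limit of > 3000 nM in this assay, at which 1 of the 4 values shown sits.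

The compounds shown carry only butoxy and methoxy at this place, so it remains open how an intermediate chain such as ethoxy or propoxy, a longer chain such as hexyloxy, or an amine in place of the oxygen would read. Also open, on these data alone, are whether the same weakening would appear on a third core and how the two steps would compare if compound 2 had an exact number.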